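This account rests on a few compounds, and the source may have more. Where it says the series, first, only, none or still open, it means among the compounds named here.

Among the measured compounds shown here, compound 1, with the structure `NC1=NC2(CCSCC2)N(OCCCOc2cccc(Cl)c2Cl)C(N)=N1`, is the only member of this small set with a number attached. In a functional assay on HepG2 cells (Homo sapiens) for antiproliferative activity, read by MTT assay, with a stated time of 72 h (a higher number here means a weaker inhibitor, a lower number a stronger inhibitor), compound 1 gives 50 nM. A second entry, compound 2 with the structure `NC1=NC2(CCOCC2)N(OCCCOc2ccccc2)C(N)=N1`, stands beside it but without a result: in this assay compound 2 is recorded as "not determined" (no result reported), so nothing can be read from it about how the two relate. For the measured compounds named here, with one number and no second measured compound, no step between measured compounds exists, and the only guidance for what follows is compound 1 itself.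

The next compound, compound 3, has the structure `NC1=NC2(CCSCC2)N(OCCCOc2cccc(Br)c2)C(N)=N1`. It keeps the shared core of compound 1 and differs in one place: 3-bromophenyl in place of 2,3-dichlorophenyl on an oxygen on a saturated carbon. Two halogens on the aromatic ring give way to a single one, and the ring is otherwise unchanged. Without a measured pair to lean on, the step from compound 1 to compound 3 in this assay is expected to be small and toward a weaker inhibitor, at or a little beyond the usual scatter, as a 2.4-fold higher number from compound 1 to compound 3 (0.38 log units; beyond the scatter). For compound 3 the expected value is 120 nM, with a range from 40 nM to 400 nM.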

Compound 3, half-maximal inhibitory concentration: 90 nM
For compound 3 the middle estimate is 1.3-fold (0.12 log units) above the measured one; the range from low to high includes it.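

Among the compounds shown here, this is the first measured step at this place on the shared core. In this assay, 3-bromophenyl in place of 2,3-dichlorophenyl on an oxygen on a saturated carbon gives a 1.8-fold higher number from compound 1 to compound 3 (0.26 log units; within the scatter), so the two compounds cannot be told apart in this read-out, and a single bromine on the aromatic ring serves as well here as two chlorines. Nothing available explains this result or shows whether the halogens matter to the cells' response.

Still open, going by these compounds, is whether the aromatic ring needs any halogen at all: compound 2 carries a plain phenyl, but it has no result and also differs from compound 1 in more than one place, so it cannot settle the question. On these data alone, it is equally open whether a ring bearing an amine or a carboxylic acid in place of the halogens would keep a number like those of compound 1 and compound 3, and whether a longer chain to the aromatic ring would do the same.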